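This account rests on a few compounds, and the source may have more. Where it says the series, first, only, none or still open, it means among the compounds named here.

Values in a functional assay on the whole organism (brain) with Mus musculus as the target; a higher number here means that more compound is needed for the effect, a lower number that less compound is needed:
compound 1 `CC(=O)c1ccc(OCCc2c[nH]cn2)cc1`: 3.2 mg/kg
compound 2 `O=C(c1ccccc1)c1ccc(OCCc2c[nH]cn2)cc1`: 2.6 mg/kg
compound 3 `O=C(c1ccc(OCCc2c[nH]cn2)cc1)N1CCCCC1`: > 10 mg/kg (a limit of the assay)

Compound 1, at 3.2 mg/kg, sits level with compound 2 within the scatter: a 1.2-fold lower number from compound 1 to compound 2 (0.09 log units; within the scatter). Compound 3 gives only a limit, > 10 mg/kg.

Compound 4 `Brc1ccc(OCCc2c[nH]cn2)cc1` departs from compound 1 by bromo in place of acetyl on an aromatic carbon, para to a group of 8 heavy atoms. Within the data shown here, no measured step removes the carbonyl, so the evidence bears on this change only indirectly. Exchanging the group on the carbonyl for phenyl gives a 1.2-fold lower number from compound 1 to compound 2 (0.09 log units; within the scatter). Exchanging it for piperidin-1-yl gives an at least 3.1-fold higher number from compound 1 to compound 3 (0.49 log units; beyond the scatter), and from the phenyl compound an at least 3.8-fold higher number from compound 2 to compound 3 (0.58 log units; beyond the scatter). Only the piperidin-1-yl change therefore moves the number beyond the scatter, and it does so upward. With compound 3 the sole such case, no step beyond the scatter is expected, though a rise remains possible, so the range is wider on the high side.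

The expected size is a 1.1-fold lower number from compound 1 to compound 4 (0.03 log units; within the scatter). Compound 4 is estimated at 3 mg/kg, with an expected range of 1 mg/kg to 9 mg/kg.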

Compound 4, dose for half-maximal effect: 2.9 mg/kg
Compound 4: the middle estimate sits 1.0-fold (0.01 log units) above what was measured; measured number inside the range.
By their numbers in this assay, from the lowest: compounds 2, 4 and 1 (each within the scatter of the next). At a limit, above all of these: compound 3.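

In this assay, bromo in place of acetyl on an aromatic carbon gives a 1.1-fold lower number from compound 1 to compound 4 (0.04 log units; within the scatter), so the effect at this position does not depend on a carbonyl, which every earlier compound carried there. The exchange also removes the sole hydrogen-bond acceptor of the acetyl group and reduces its 3 heavy atoms to 1, with no step beyond the scatter. Compound 3 therefore remains the only compound in the series to stand apart, and its value is a limit: the limit of > 10 mg/kg in this assay, at which 1 of the 4 values shown sits.

As far as these compounds go, it remains open whether the level numbers extend to other groups on this carbon, such as an amine, a carboxylic acid or a longer chain. The data also do not show whether the rise with compound 3 belongs to the piperidin-1-yl ring alone.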